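The compounds below may be only part of what the source reports. "The series", "measured", "known", "first", "only" and "open" are said of these compounds alone.

Going by the values given here, in a functional assay on NCI-H460 cells (Homo sapiens) for cytotoxicity, read by sulforhodamine B assay, with a stated time of 3 days (a lower number here means a stronger inhibitor, a higher number a weaker inhibitor), compound 1 `O=Cc1cn(Cc2cccc(Br)c2)c2ccccc12` gives 39 nM while compound 2 `O=Cc1cn(Cc2ccc(Br)c(Br)c2)c2ccccc12` gives 63 nM and so stands within the scatter of the only other measured compound. Compound 3 `OCc1cn(Cc2ccc(Br)c(Br)c2)c2ccccc12` differs from compound 2 by hydroxymethyl in place of formyl on an aromatic carbon and by nothing else. Among the compounds with values here, the one measured step of a 1.6-fold higher number from compound 1 to compound 2 (0.21 log units; within the scatter) is bromo in place of hydrogen and does not test this swap, so no step beyond the scatter is expected in this assay and the range stays wide. The expected step of a 1.1-fold lower number from compound 2 to compound 3 (0.02 log units; within the scatter) is therefore small. Compound 3 is expected at 60 nM with an estimated range from 15 nM to 250 nM as its likely span.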

Compound 3, half-maximal inhibitory concentration: 50 nM
Compound 3: the middle estimate sits 1.2-fold (0.08 log units) above what was measured; measured number inside the range.
By their numbers in this assay, from the lowest: compounds 1, 3 and 2 (each within the scatter of the next).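

In this assay the change to hydroxymethyl in place of formyl, on the aromatic carbon two ring bonds from the ring nitrogen, gives a 1.3-fold lower number from compound 2 to compound 3 (0.10 log units; within the scatter) and so stays small. At this position, then, the number did not depend on keeping the formyl double bond, and a hydrogen-bond donor entered without a step beyond the scatter. No measured evidence bears on why this is so.
The compounds shown leave open whether an amine, a carboxylic acid or a longer chain on this carbon would keep the number in this range. They also leave open whether hydroxymethyl would behave alike on the core of compound 1.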